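Closing the diethylamino of Compound 3 into a Ring

The source may report more compounds than this note shows. Statements on the series, on what has been measured and on what is new or still open speak of the compounds shown alone.

Compound 1 `CCCNc1cnn(C)c(=O)c1OCC`: 38%
Compound 2 `CCOc1c(N(C)C)cnn(C)c1=O`: 49.5%
Compound 3 `CCOc1c(N(CC)CC)cnn(C)c1=O`: 32.5%

Three compounds share one core and differ only in the amine on an aromatic carbon. In a functional assay on the whole organism (strain Wistar) for inhibition, with Rattus norvegicus as the target, read by paw edema, with stated times of 30 min and 3 h, at a dose of 100 mg/kg by the oral route (a higher number here means a stronger effect of the compound at the dose given, a lower number a weaker effect), compound 1 gives 38%, compound 2 gives 49.5% and compound 3 gives 32.5%. Compound 3 stands lowest of the three, though its gap to compound 1 lies within the scatter; only a number 17 percentage points lower from compound 2 to compound 3 (beyond the scatter) lies beyond it. Compound 4 `CCOc1c(N2CCCC2)cnn(C)c1=O` is not yet measured; it differs from compound 3 by pyrrolidin-1-yl in place of diethylamino on an aromatic carbon. Among the measured compounds shown here, no measured step exchanges an open-chain amine for a ring, so the bearing steps are indirect: a number 17 percentage points lower from compound 2 to compound 3 (beyond the scatter) and a number 5.5 percentage points lower from compound 1 to compound 3 (within the scatter). The step for compound 4 is therefore expected to be a number 7.5 percentage points higher from compound 3 to compound 4 (within the scatter), not necessarily beyond the scatter. Compound 4 is estimated at 40%, in the range 25% to 55%.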

Compound 4, a percentage reported as inhibition, in the whole organism at one dose (the size of the read-out at that dose, not a potency): 23%
Beside the measured number, compound 4's estimate is 17 percentage points above it, and the stated range ends above it.
By their numbers in this assay, from the lowest: compounds 4, 3 and 1 (each within the scatter of the next, the first and the last beyond it); then compound 2.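

In this assay pyrrolidin-1-yl in place of diethylamino at this position gives a number 9.5 percentage points lower from compound 3 to compound 4 (within the scatter) and so closing the same heavy atoms into a ring does not lift the effect above that of the open amine. The ring does, however, separate from the other two open amines, with a number 26.5 percentage points lower from compound 2 to compound 4 (beyond the scatter) and a number 15 percentage points lower from compound 1 to compound 4 (beyond the scatter) as the steps. Nothing measured here explains these differences.

Going by these compounds, whether a six-membered ring such as piperidin-1-yl or morpholin-4-yl would behave like pyrrolidin-1-yl stays open. So does whether dimethylamino would keep its place with a longer chain in place of the ethoxy group.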